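This account rests on a few compounds, and the source may have more. Where it says the series, first, only, none or still open, it means among the compounds named here.

Measured so far, in an ADME assay on TZM-b1 cells (Homo sapiens) for cytotoxicity, read by XTT assay, with a stated time of 3 days; a higher number here means that more compound is tolerated, a lower number that less compound is tolerated:

- compound 1 `Cc1nc(C(NC(=O)C(=O)Nc2ccc(Cl)cc2)C2CCCCN2)sc1CO` gives > 22000 nM, a limit of the assay.
- compound 2 `Cc1nc(C(NC(=O)C(=O)Nc2ccc(F)c(Cl)c2)C2CCCCN2)sc1CO` gives > 77800 nM, a limit of the assay.
- compound 3 `Cc1ccc(NC(=O)C(=O)NC(c2nc(C)c(CO)s2)C2CCCCN2)cc1F` gives > 88000 nM, a limit of the assay.

All three values in this assay are limits rather than numbers, as the limit of > 22000 nM in this assay, at which 1 of the 3 values shown sits, the limit of > 77800 nM in this assay, at which 1 of the 3 values shown sits, and the limit of > 88000 nM in this assay, at which 1 of the 3 values shown sits, show. Consequently the steps between them are not readable: a step that the two limits leave unreadable from compound 1 to compound 2, a step that the two limits leave unreadable from compound 1 to compound 3 and a step that the two limits leave unreadable from compound 2 to compound 3 give no size and no direction. Compound 3 therefore stands only at a limit, alongside two further limits, and nothing in the measured set separates it from compound 1 or compound 2.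

Compound 4 `CC(=O)c1ccc(NC(=O)C(=O)NC(c2nc(C)c(CO)s2)C2CCCCN2)cc1` differs from compound 3 by 4-acetylphenyl in place of 3-fluoro-4-methylphenyl on an amide-type nitrogen. The three measured steps all concern changes of the aryl group on the same amide-type nitrogen, and each of them is left unreadable by the limits, so no measured size can be carried over to the present change. What the set does show is that three different aryl groups at this position were all tolerated up to the limit of this assay.

On that basis compound 4 is expected to behave the same way, with an estimated value of 80000 nM and a range of 20000 nM to 200000 nM, most likely reported again as a limit. The expected step of an at least 1.1-fold lower number from compound 3 to compound 4 (0.04 log units; that floor lies within the scatter) is none beyond the scatter.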

Compound 4, half-maximal cytotoxic concentration: > 86000 nM
Compound 4: no number, only a limit; the forecaster's own chance of this, stated with the estimate: 85%; middle value at least 1.0-fold (0.03 log units) from the limit.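

In this assay compound 4 gives > 86000 nM, again a limit of the assay and not a number. The steps linking compound 4 to compound 1, compound 2 and compound 3 cannot be read, in either size or direction. The compounds shown leave open the concentration at which any of these four compounds becomes cytotoxic.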